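Chlorophenyl replaces ethoxy-hydroxyphenyl on the shared core

A few compounds are considered here, and "the series" means these few. Any claim that something is new, unique, unknown or untested is made for them only; others in the source may bear on it.

In an ADME assay on HEK293 cells (Homo sapiens) for cytotoxicity, read by MTT assay, with a stated time of 48 h (a lower number here means a stronger inhibitor, a higher number a weaker inhibitor), compound 1 `O=C1/C(=C\c2ccc(Cl)cc2)S/C(=N/c2ccccc2)N1Cc1ccncc1` gives 42300 nM and compound 2 `CCOc1cc(/C=C2/S/C(=N/c3ccccc3)N(Cc3ccncc3)C2=O)ccc1O` gives 46500 nM. These two numbers lie within the scatter of each other, so compound 2 cannot be set apart from compound 1. Compound 3 `O=C1/C(=C\c2cccc(Cl)c2)S/C(=N/c2ccccc2)N1Cc1ccncc1` differs from compound 2 in one group: 3-chlorophenyl in place of 3-ethoxy-4-hydroxyphenyl on a double-bonded chain carbon bound to a double-bonded ring carbon. It carries 3-chlorophenyl, where compound 1 carries 4-chlorophenyl. Among the measured compounds shown here, the only measured step that bears on this change is a 1.1-fold higher number from compound 1 to compound 2 (0.04 log units; within the scatter), which involves the same 3-ethoxy-4-hydroxyphenyl group and stays within the scatter. For the measured compounds named here, no measured compound carries 3-chlorophenyl, so that group's own contribution is untested. No step beyond the scatter is therefore expected in this assay, in either direction. The estimated step is a 1.1-fold lower number from compound 2 to compound 3 (0.03 log units; within the scatter). For compound 3 the expected value is 43000 nM, with an estimated range of 24000 nM to 78000 nM.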

Compound 3, half-maximal inhibitory concentration: 71800 nM
For compound 3 the middle estimate is 1.7-fold (0.22 log units) below the measured one; the measured number falls inside the stated range.
By their numbers in this assay, from the lowest: compounds 1, 2 and 3 (each within the scatter of the next).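

In this assay, 3-chlorophenyl in place of 4-chlorophenyl gives a 1.7-fold higher number from compound 1 to compound 3 (0.23 log units; within the scatter), and 3-chlorophenyl in place of 3-ethoxy-4-hydroxyphenyl gives a 1.5-fold higher number from compound 2 to compound 3 (0.19 log units; within the scatter). On a double-bonded chain carbon bound to a double-bonded ring carbon, the three groups now tested cannot be set apart, although 3-chlorophenyl has no hydrogen-bond donor or acceptor and 3-ethoxy-4-hydroxyphenyl has both. No evidence at hand speaks to why these compounds cannot be told apart.

All three compounds carry a substituted phenyl group at this place, so they leave open whether an amine, a carboxylic acid or a longer chain there would give a step beyond the scatter. The rest of the shared core is the same throughout, so they also say nothing about changes elsewhere on it.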